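Amide group swap from compound 3 to compound 4

This account rests on a few compounds, and the source may have more. Where it says the series, first, only, none or still open, it means among the compounds named here.

In a functional assay on HeLa cells (Homo sapiens) for inhibition, read by CCK-8 assay, with a stated time of 72 h, tested at 1 uM (on this read-out higher numbers stand for more inhibition of growth at the one concentration tested and lower numbers for less inhibition of growth), compound 1 (`CN(C)C(=O)c1cc2cnc(Nc3ccc(NC(=O)C4(C(=O)Nc5ccc(F)cc5)CC4)cc3)nc2n1C1CCCC1`) gives 49.8% and compound 2 (`CN(C)C(=O)c1cc2cnc(Nc3ccc(NC(=O)C4(C(=O)Nc5cccc(O)c5)CC4)cc3)nc2n1C1CCCC1`) gives 57% on the same read-out. Compound 3 (`CN(C)C(=O)c1cc2cnc(Nc3ccc(NC(=O)C4(C(=O)Nc5ccc(Cl)c(C(F)(F)F)c5)CC4)cc3)nc2n1C1CCCC1`) stands lowest of the three at 16.5% in this set. Both steps down to it are large and beyond the scatter (a number 33.3 percentage points lower from compound 1 to compound 3 (beyond the scatter)) and (a number 40.5 percentage points lower from compound 2 to compound 3 (beyond the scatter)).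

The unmeasured compound 4 (`CN(C)C(=O)c1cc2cnc(Nc3ccc(NC(=O)C4(C(=O)Nc5ccc(O)cc5)CC4)cc3)nc2n1C1CCCC1`) carries 4-hydroxyphenyl in place of 4-chloro-3-(trifluoromethyl)phenyl on an amide-type nitrogen. The nearest evidence is compound 2, which holds 3-hydroxyphenyl at that place and lies far from compound 3 (a number 40.5 percentage points lower from compound 2 to compound 3 (beyond the scatter)). Compound 1, with 4-fluorophenyl, also lies far from compound 3 (a number 33.3 percentage points lower from compound 1 to compound 3 (beyond the scatter)), while the two groups in compound 1 and compound 2 stay within the scatter of each other (a number 7.2 percentage points higher from compound 1 to compound 2 (within the scatter)). Going by the values given here, no measured compound holds 4-hydroxyphenyl itself, so the range is kept wide.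

In this assay a large upward step beyond the scatter is therefore expected, estimated as a number 35.5 percentage points higher from compound 3 to compound 4 (beyond the scatter) on this evidence. For compound 4 the estimated value is 52% and the expected range runs from 36% up to 68% on that reading.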

Compound 4, percent growth inhibition at one concentration: 62.3%
Compound 4: middle estimate off by 10.3 percentage points, on the low side, within the range that was stated.
By their numbers in this assay, from the lowest: compound 3; then compounds 1, 2 and 4 (each within the scatter of the next, the first and the last beyond it).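

In this assay, 4-hydroxyphenyl on the amide-type nitrogen recovers all of the ground lost with 4-chloro-3-(trifluoromethyl)phenyl (a number 45.8 percentage points higher from compound 3 to compound 4 (beyond the scatter)), so this place tolerates a hydroxy-bearing ring in a second arrangement, not only the 3-hydroxyphenyl of compound 2. The two hydroxyphenyl groups cannot be told apart here (a number 5.3 percentage points higher from compound 2 to compound 4 (within the scatter)), so the compounds shown give no preference for either arrangement of the hydroxy group. Hydroxy in place of fluoro on the aromatic carbon gives a modest step beyond the scatter (a number 12.5 percentage points higher from compound 1 to compound 4 (beyond the scatter)), but the pattern is not general, since compound 2, also a hydroxyphenyl, stays within the scatter of the 4-fluorophenyl group (a number 7.2 percentage points higher from compound 1 to compound 2 (within the scatter)).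

No measurement on hand accounts for any of these steps. Whether the hydroxy hydrogen itself matters stays open, as 4-methoxyphenyl, 4-aminophenyl, 4-carboxyphenyl and plain phenyl on the same nitrogen lie outside the compounds shown, and a reading at one concentration leaves the full dose response of compound 2 and compound 4 unresolved.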